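Methyl to Trifluoromethyl: Expected Potency of Compound 4

The source may hold more compounds than are shown below. What is called first, only, known or untested is meant among the compounds shown, and "the series" means these compounds.

Compound 1, `CC(O)(C(=O)Nc1ccc(S(=O)(=O)c2ccccc2)c(F)c1)C(F)(F)F`, in a functional assay (Cavia porcellus) with sulfonylurea receptors; K-ATP channels (Homo sapiens) as the target (a lower number here means a stronger inhibitor, a higher number a weaker inhibitor), compound 1 gives 1800 nM.
Compound 2, `CC(O)(C(=O)Nc1ccc(S(=O)(=O)c2ccccc2)c(O)c1)C(F)(F)F`, compound 2 gives 430 nM.
Compound 3, `Cc1cc(NC(=O)C(C)(O)C(F)(F)F)ccc1S(=O)(=O)c1ccccc1`, compound 3 gives 1600 nM.

Among these three, compound 3 stands second highest. Its number and that of compound 1 lie within the usual scatter of each other, so the two cannot be told apart: a 1.1-fold lower number from compound 1 to compound 3 (0.05 log units; within the scatter). Compound 2 gives the lowest number of the three, and the step of a 3.7-fold higher number from compound 2 to compound 3 (0.57 log units; beyond the scatter) is a modest one beyond the scatter.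

Compound 4, `CC(O)(C(=O)Nc1ccc(S(=O)(=O)c2ccccc2)c(C(F)(F)F)c1)C(F)(F)F`, is not yet measured. It differs from compound 3 in one place: trifluoromethyl in place of methyl on an aromatic carbon.

Among the compounds with values here, no measured step puts a trifluoromethyl group at that position, so the expectation rests on what the neighbouring changes show. Replacing fluoro by methyl there left the number essentially unchanged, a 1.1-fold lower number from compound 1 to compound 3 (0.05 log units; within the scatter), whereas hydroxy in that place gave the lower number of compound 2, a 4.2-fold lower number from compound 1 to compound 2 (0.62 log units; beyond the scatter). A trifluoromethyl group shares no hydrogen-bond donor or acceptor with hydroxy, so the most likely outcome is a number close to that of compound 3, with at most a small shift towards weaker inhibition.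

For compound 4 the estimated value in this assay is 2000 nM, in the range 800 nM to 5000 nM, which would mean an expected step of a 1.3-fold higher number from compound 3 to compound 4 (0.10 log units; within the scatter).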

Compound 4, half-maximal inhibitory concentration: > 30000 nM
Compound 4: no number, only a limit; the forecaster's own chance of this, stated with the estimate: 5%; middle value at least 15-fold (1.17 log units) from the limit.
By their numbers in this assay, from the lowest: compound 2; then compounds 3 and 1 (each within the scatter of the next). At a limit, above all of these: compound 4.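

Within the data shown here, the position proved far less forgiving than the earlier compounds suggested: fluoro and methyl could not be told apart there, yet trifluoromethyl gives an at least 18-fold higher number from compound 3 to compound 4 (1.27 log units; beyond the scatter) and an at least 16-fold higher number from compound 1 to compound 4 (1.22 log units; beyond the scatter). Against hydroxy, the group with the lowest number among those shown, the change gives an at least 69-fold higher number from compound 2 to compound 4 (1.84 log units; beyond the scatter). Compound 4 has no exact number in this assay, only a limit, and methyl and trifluoromethyl both count 0 hydrogen-bond donors and 0 acceptors, so that count does not separate them: the limit of > 30000 nM in this assay, at which 1 of the 4 values shown sits.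

The compounds shown do not tell whether the loss follows the larger heavy-atom count of trifluoromethyl or something particular to its fluorines, a question that an ethyl group or a chlorine atom at this position could address. As far as these compounds go, whether an amine could match the lower number seen with hydroxy also remains open.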